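Benzamide series: sulfur-linked aryl to phenethyl swap

A few compounds are considered here, and "the series" means these few. Any claim that something is new, unique, unknown or untested is made for them only; others in the source may bear on it.

Measured compounds:
- compound 1, `Nc1ccccc1NC(=O)/C=C/c1ccc(CSc2ccc(F)cc2)cc1`, 18.3%
- compound 2, `Nc1ccccc1NC(=O)c1ccc(CSc2cccc(F)c2)cc1`, 18.6%
- compound 3, `Nc1ccccc1NC(=O)c1ccc(CSc2ccc(Cl)cc2)cc1`, 2.93%

In a functional assay on SMMC-7721 cells (Homo sapiens) for inhibition, read by CCK-8 assay, with a stated time of 72 h, tested at 2 uM (on this read-out lower numbers stand for less inhibition of growth and higher numbers for more inhibition of growth at the one concentration tested), compound 1 stands second highest of the three numbers. Its nearest neighbour is compound 2, whose value lies within the scatter of that of compound 1, so no order between the two can be read. Compound 3 sits furthest away, beyond the scatter. For the measured compounds named here, the only single-point step among the measured compounds is a number 15.7 percentage points lower from compound 2 to compound 3 (beyond the scatter), an exchange of one aryl group for another on the sulfur.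

Compound 4, `Nc1ccccc1NC(=O)/C=C/c1ccc(CSCCc2ccccc2)cc1`, is not yet measured. It differs from compound 1 as follows: phenethyl in place of 4-fluorophenyl on a sulfur. Going by the values given here, this is not an aryl-for-aryl exchange; no measured step covers a switch from an aryl to a saturated-linked phenyl on the sulfur, so the step from compound 2 to compound 3 bears on it only loosely, as the one sign that changes at this position can move the read-out by a modest amount.

Among the compounds with values here, with no direct precedent, the expectation for compound 4 is a number near that of compound 1, with a wide range to allow a modest shift in either direction; the expected step is a number 3.3 percentage points lower from compound 1 to compound 4 (within the scatter). Compound 4 is estimated at 15%, between 0% and 30%.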

Compound 4, percent growth inhibition at one concentration: 14.7%
Compound 4: middle estimate off by 0.3 percentage points, on the high side, within the range that was stated.
By their numbers in this assay, from the lowest: compound 3; then compounds 4, 1 and 2 (each within the scatter of the next).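

In this assay, phenethyl in place of 4-fluorophenyl on a sulfur gives a number 3.6 percentage points lower from compound 1 to compound 4 (within the scatter) and so no order can be read between the two compounds. For the compounds shown here, this position on the core of compound 1 therefore accepts a phenyl held away from the sulfur by a saturated chain, with the fluorine absent, and no shift in growth inhibition can be read at the one concentration tested; the earlier compounds held only aryl groups directly on the sulfur, so this is the first sign that the aryl link itself is not required for a read-out of this size, though it rests on a single pair. No supporting data on hand speak to the reason for this result.

Since the link and the fluorine change together in this pair, the compounds shown do not separate the part played by each, and a fluorine on the phenyl ring of phenethyl would be needed to do so. Also open, from the compounds shown here alone, is whether a longer chain on the sulfur, or an amine or a carboxylic acid at the end of that chain, would move growth inhibition beyond the scatter.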